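This account rests on a few compounds, and the source may have more. Where it says the series, first, only, none or still open, it means among the compounds named here.

Compound 1 `C/C(=C\c1cc(-c2ccc(F)cc2)co1)C(N)=O` in a functional assay on MCF7 cells (Homo sapiens) for cytotoxicity, read by CCK-8 assay, with a stated time of 24 h (a higher number here means a weaker inhibitor, a lower number a stronger inhibitor), gives 2210 nM. Compound 2 `C/C(=C\c1cc(-c2ccc(C)cc2)cs1)C(N)=O` is known in this assay only as a limit, > 50000 nM, and therefore stands at the limit of > 50000 nM in this assay, at which 1 of the 2 values shown sits. Compound 3 `C/C(=C\c1cc(-c2ccc(Cl)cc2)cs1)C(N)=O` differs from compound 2 by chloro in place of methyl on an aromatic carbon. Among the compounds with values here, no measured pair isolates this change. Because compound 2 is fixed only by the limit of > 50000 nM in this assay, at which 1 of the 2 values shown sits, no direction is read for the step; the expected change is an at least 1.4-fold lower number from compound 2 to compound 3 (0.15 log units; that floor lies within the scatter), taken as within the scatter. Compound 3 is estimated at 35000 nM, with a range of 7000 nM to 150000 nM.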

Compound 3, half-maximal inhibitory concentration: 17100 nM
Beside the measured number, compound 3's estimate is 2.0-fold (0.31 log units) above it; the range from low to high includes it.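

Chloro in place of methyl on an aromatic carbon, para to a large group, gives the first readable step at this position: in this assay the change gives an at least 2.9-fold lower number from compound 2 to compound 3 (0.46 log units; beyond the scatter). Compound 2 is known only as a limit, so this size is a floor and not a measured gap: the limit of > 50000 nM in this assay, at which 1 of the 3 values shown sits. The number at this position therefore responds to this change by more than the usual scatter.

Compound 1 differs from compound 3 in more than one place, so no comparison between them can be read. From the compounds shown here alone, how a methoxy group or an amine would stand at this position remains open.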